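Coumarin-bearing pyrazolines: an amino acyl chain variant

A few compounds are considered here, and "the series" means these few. Any claim that something is new, unique, unknown or untested is made for them only; others in the source may bear on it.

Among the compounds with values here, the three compounds measured so far share a pyrazoline core. Compound 1 `CC1=NN(C(=O)c2ccc([N+](=O)[O-])cc2)C(c2ccccc2O)C1` carries a nitrobenzoyl group and gives 36600 nM in a functional assay on PC-3 cells (Homo sapiens) for cytotoxicity, read by MTT assay, with a stated time of 48 h; on this read-out higher numbers stand for weaker inhibition and lower numbers for stronger inhibition. Compound 2 `CC1=NN(C(=O)CN2CCCCC2)C(c2ccccc2O)C1` gives 5890 nM in this assay. Compound 3 `CCC(=O)N1N=C(c2cc3ccccc3oc2=O)CC1c1ccccc1`, which bears a coumarin substituent and a propanoyl chain, gives 4370 nM. Compound 3 holds the lowest number of the three; the gap to compound 2 lies within the scatter, so no order between those two can be claimed, while the gap to compound 1 lies beyond it.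

Compound 4 `CCNCC(=O)N1N=C(c2cc3ccccc3oc2=O)CC1c1ccccc1` has not been measured. It differs from compound 3 by ethylamino in place of methyl on a saturated chain carbon bound to a carbonyl carbon. Within the data shown here, no measured pair shows this change, so nothing beyond the scatter is expected: compound 2, which also carries an amine on the acyl chain, gives a number close to compound 3. The step from compound 3 to compound 4 is expected to be a 1.1-fold lower number from compound 3 to compound 4 (0.04 log units; within the scatter), within the scatter. Compound 4 is estimated at 4000 nM, with a range from 1500 nM to 12000 nM.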

Compound 4, half-maximal inhibitory concentration: 5580 nM
For compound 4 the middle estimate is 1.4-fold (0.14 log units) below the measured one, within the range that was stated.
By their numbers in this assay, from the lowest: compounds 3, 4 and 2 (each within the scatter of the next); then compound 1.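

In this assay, within the data shown here, ethylamino in place of methyl on a saturated chain carbon bound to a carbonyl carbon gives a 1.3-fold higher number from compound 3 to compound 4 (0.11 log units; within the scatter), the first step that can be read at this position. The entering group brings a nitrogen, a hydrogen-bond donor and a hydrogen-bond acceptor to the propanoyl chain, yet no change beyond the scatter appears, so this position accepts the exchange with no measurable penalty on this read-out. Nothing measured here explains why the number holds across this change.

Still open, as far as these compounds go, is whether a morpholine, a carboxylic acid or a longer chain such as butylamino on the same carbon would move the number beyond the scatter. From the compounds shown here alone, whether ethylamino gives a similar step on other acyl chains also remains unknown.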